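Adding chloro to compound 3 in a cell assay

The source may hold more compounds than are shown below. What is called first, only, known or untested is meant among the compounds shown, and "the series" means these compounds.

Compound 1 `O=C(C=CNc1cc(-c2ccccc2)nn1-c1ccccc1)c1ccc(Br)cc1` gives 21700 nM
Compound 2 `O=C(C=CNc1cc(-c2ccccc2)nn1-c1ccccc1)c1cccs1` gives 15400 nM
Compound 3 `O=C(C=CNc1cc(-c2ccccc2)nn1-c1ccccc1)c1ccccc1` gives 9650 nM

These three values come from a functional assay on MCF7 cells (Homo sapiens) for inhibition, read by MTT assay, with a stated time of 48 h (on this read-out higher numbers stand for weaker inhibition and lower numbers for stronger inhibition), and the compounds differ only in the group on the carbonyl carbon. Compound 3 (9650 nM) sits at the low end of the three values. One measured step (a 1.6-fold lower number from compound 2 to compound 3 (0.20 log units; within the scatter)) leaves it level with the thiophen-2-yl compound. Another (a 2.2-fold lower number from compound 1 to compound 3 (0.35 log units; beyond the scatter)) sets it apart from the 4-bromophenyl compound.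

Within the data shown here, the next compound to consider is compound 4 `O=C(C=CNc1cc(-c2ccccc2)nn1-c1ccccc1)c1ccc(Cl)cc1` and its one change from compound 3 is chloro in place of hydrogen on an aromatic carbon, para to a large group (chloro in place of hydrogen on an aromatic carbon). This turns phenyl into 4-chlorophenyl. The closest guide is compound 1, which has 4-bromophenyl at that place. Its step (a 2.2-fold lower number from compound 1 to compound 3 (0.35 log units; beyond the scatter)) is modest, and read in reverse it points towards a higher number when the hydrogen is replaced. Among the measured compounds shown here, this is a single case, and no chloro compound has yet been measured. The step involving the thiophen-2-yl group (a 1.4-fold lower number from compound 1 to compound 2 (0.15 log units; within the scatter)) alters a whole ring and bears on the change less directly.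

A rise no larger than that one is therefore expected, and the estimated step is a 1.6-fold higher number from compound 3 to compound 4 (0.19 log units; within the scatter) as a best guess. For compound 4 the estimated value is 15000 nM (expected range 8000 nM to 27000 nM).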

Compound 4, half-maximal inhibitory concentration: 8070 nM
For compound 4 the middle estimate is 1.9-fold (0.27 log units) above the measured one; low and high end bracket the measured number.
By their numbers in this assay, from the lowest: compounds 4, 3, 2 and 1 (each within the scatter of the next, the first and the last beyond it).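

In this assay, the step with chloro in place of hydrogen (a 1.2-fold lower number from compound 3 to compound 4 (0.08 log units; within the scatter)) shows that a halogen at this place on the phenyl ring need not go with a higher number, as the single bromo case had suggested. The bromo compound now stands apart from both the unsubstituted compound and the chloro compound: the exchange of bromo for chloro (a 2.7-fold lower number from compound 1 to compound 4 (0.43 log units; beyond the scatter)) lies beyond the scatter, so the two halogens are not interchangeable here, even though each step is modest. The whole-ring exchange (a 1.9-fold lower number from compound 2 to compound 4 (0.28 log units; within the scatter)) leaves compound 4 level with the thiophen-2-yl compound, so three of the four groups now lie close together and only the 4-bromophenyl compound, at the high end, is set apart from compound 3 and compound 4; nothing shown here accounts for this difference between chloro and bromo.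

The compounds shown leave open whether fluoro, methoxy, an amine or a carboxylic acid at this place would stay level with hydrogen and chloro or follow bromo. They also leave open whether the gap between chloro and bromo would persist with these groups elsewhere on the ring.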